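Quinoline carboxamides against Hep 3B2 cells: three measured, one open

The source may hold more compounds than are shown below. What is called first, only, known or untested is meant among the compounds shown, and "the series" means these compounds.

Measured compounds:
compound 1, `CCc1ccc2nc(C(=O)Nc3c(F)cc(-c4cccc(F)c4)cc3F)c(C)c(O)c2c1`, 2.05%
compound 2, `Cc1c(C(=O)Nc2c(F)cc(-c3cccc(F)c3)cc2F)nc2ccc(F)cc2c1O`, 0.35%
compound 3, `CCc1ccc2nc(C(=O)Nc3c(F)cc(-c4cccc(F)c4)cc3F)c(C)c(C(=O)O)c2c1`, -0.05%

In a functional assay on Hep 3B2 cells (Homo sapiens) for antiproliferative activity, read by MTT assay, with a stated time of 24 h, tested at 0.02 ug/mL (a lower number here means a weaker effect, a higher number a stronger effect of the compound at the concentration tested), compound 1 gives 2.05%. Compound 2 differs from it by fluoro in place of ethyl on an aromatic carbon, and the step is a number 1.7 percentage points lower from compound 1 to compound 2 (within the scatter). Compound 3 carries a second core, differing from compound 1 by carboxy in place of hydroxy on an aromatic carbon; in this assay compound 3 gives -0.05%, and the step is a number 2.1 percentage points lower from compound 1 to compound 3 (within the scatter). All three numbers lie within the scatter of one another, so no order among them can be read.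

Compound 4, `Cc1c(C(=O)Nc2c(F)cc(-c3cccc(F)c3)cc2F)nc2ccc(F)cc2c1C(=O)O`, is not yet measured. It differs from compound 3 by fluoro in place of ethyl on an aromatic carbon, which is the same change as that from compound 1 to compound 2, made at the same place on the core of compound 3. Because the earlier step was a number 1.7 percentage points lower from compound 1 to compound 2 (within the scatter), compound 4 is expected to stay near compound 3, with an estimated step of a number 1 percentage points lower from compound 3 to compound 4 (within the scatter). The estimate for compound 4 in this assay is therefore -1%, expected between -8% and 6%.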

Compound 4, a percentage reported as inhibition, at one concentration (the size of the read-out at that concentration, not a potency): -0.13%
Compound 4: middle estimate off by 0.9 percentage points, on the low side; the range from low to high includes it.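

In this assay, fluoro in place of ethyl on an aromatic carbon gives a step of a number 0.1 percentage points lower from compound 3 to compound 4 (within the scatter), and this agrees with the same change on the other core: the same change on two cores in this assay, a number 1.7 percentage points lower (within the scatter) from compound 1 to compound 2 and a number 0.1 percentage points lower (within the scatter) from compound 3 to compound 4, 1.6 percentage points apart, within the scatter of two such steps

Carboxy in place of hydroxy on an aromatic carbon gives a step of a number 0.5 percentage points lower from compound 2 to compound 4 (within the scatter), and this too agrees with its earlier counterpart: the same change on two cores in this assay, a number 2.1 percentage points lower (within the scatter) from compound 1 to compound 3 and a number 0.5 percentage points lower (within the scatter) from compound 2 to compound 4, 1.6 percentage points apart, within the scatter of two such steps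

Going by these compounds alone, this shows only that neither change gave a readable step on either core; it does not show that either change carries a fixed effect from one core to another, as every step here lies within the scatter and there is no effect of readable size to transfer.

The compounds shown leave open whether any change in this series can move the read-out beyond the scatter at this one concentration. An amine in place of the hydroxy or carboxy group, or a longer chain in place of ethyl, remains an open case, as does the behaviour of all four compounds at other concentrations.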